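From Piperidine to Isothiazole on a Shared Core

A few compounds are considered here, and "the series" means these few. Any claim that something is new, unique, unknown or untested is made for them only; others in the source may bear on it.

Compounds measured so far:
compound 1, `CCC(C)(C)Cc1c[nH]c(CCc2ccc(-c3cnccn3)cc2)n1`, 51 nM
compound 2, `CCC(C)(C)Cc1c[nH]c(CCc2ccc(N3CCCCC3)cc2)n1`, 28 nM
compound 3, `O=C(O)c1cc(F)c(F)cc1-c1ccc(CCc2nc(CC3CCCCC3)c[nH]2)cc1`, 36 nM

In an in vitro assay on CHO cells for displacement of a labelled ligand from Bombesin receptor subtype-3 (Homo sapiens), read by scintillation counting, with a stated time of 2 h (on this read-out lower numbers stand for stronger inhibition and higher numbers for weaker inhibition), compound 2 gives the lowest of the three numbers, but both compound 3 and compound 1 sit within the scatter of it, so no order among them can be claimed. Compound 4 `CCC(C)(C)Cc1c[nH]c(CCc2ccc(-c3ccns3)cc2)n1` is compound 2 with 1,2-thiazol-5-yl in place of piperidin-1-yl on an aromatic carbon. Among the compounds with values here, the one measured step that bears on this change is a 1.8-fold lower number from compound 1 to compound 2 (0.26 log units; within the scatter), where an aromatic group also stood against piperidin-1-yl; that step was within the scatter, and compound 4 returns to an aromatic group. A step of a 1.6-fold higher number from compound 2 to compound 4 (0.21 log units; within the scatter) is therefore expected, at most a modest rise. Compound 4 is estimated at 45 nM, with a range from 15 nM to 140 nM.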

Compound 4, half-maximal inhibitory concentration: 11 nM
Compound 4: the middle estimate sits 4.1-fold (0.61 log units) above what was measured; the whole stated range lies above it.
By their numbers in this assay, from the lowest: compound 4; then compounds 2, 3 and 1 (each within the scatter of the next).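

At this position, on an aromatic carbon para to a large group, the group now matters in this assay: there is a 2.5-fold lower number from compound 2 to compound 4 (0.41 log units; beyond the scatter) and a 4.6-fold lower number from compound 1 to compound 4 (0.67 log units; beyond the scatter), whereas the earlier step between the piperidin-1-yl and pyrazin-2-yl compounds stayed within the scatter. Carrying an aromatic group here is therefore not enough on its own to give the lowest number, as compound 1 also carries one. Nothing available explains why 1,2-thiazol-5-yl gives the lower number.

The compounds shown leave open whether the sulfur or the five-membered ring goes with that number, a question a thiophene or a 1,2-oxazol-5-yl group at this place would address. They also leave open how an open-chain amine such as dimethylamino would compare with piperidin-1-yl.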